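Swapping a methyl for chloro on the benzyl ring

A few compounds are considered here, and "the series" means these few. Any claim that something is new, unique, unknown or untested is made for them only; others in the source may bear on it.

Compound 1 `Cc1ccc(CSc2cc(Cl)c(C)cc2S(=O)(=O)/N=C(\N)n2nc(C)cc2-c2ccccc2)cc1`: 28000 nM
Compound 2 `Cc1cc(-c2ccccc2)n(/C(N)=N/S(=O)(=O)c2cc(C)c(Cl)cc2SCc2cccc(C(F)(F)F)c2)n1`: 19000 nM
Compound 3 `Cc1cccc(CSc2cc(Cl)c(C)cc2S(=O)(=O)/N=C(\N)n2nc(C)cc2-c2ccccc2)c1`: 34000 nM

In a functional assay on HCT-116 cells (Homo sapiens) for cytotoxicity, read by MTT assay, with a stated time of 72 h (on this read-out higher numbers stand for weaker inhibition and lower numbers for stronger inhibition), compound 3 gives the highest of the three numbers, yet its gaps to the others are small: a 1.2-fold higher number from compound 1 to compound 3 (0.08 log units; within the scatter) and a 1.8-fold higher number from compound 2 to compound 3 (0.25 log units; within the scatter). Compound 4 `Cc1cc(-c2ccccc2)n(/C(N)=N/S(=O)(=O)c2cc(C)c(Cl)cc2SCc2cccc(Cl)c2)n1` differs from compound 3 by chloro in place of methyl on an aromatic carbon. Within the data shown here, the steps that bear on this change all sit on the same benzyl ring: a 1.5-fold lower number from compound 1 to compound 2 (0.17 log units; within the scatter), a 1.2-fold higher number from compound 1 to compound 3 (0.08 log units; within the scatter) and a 1.8-fold higher number from compound 2 to compound 3 (0.25 log units; within the scatter), every one within the scatter. Among the measured compounds shown here, nothing measured so far shows this ring position moving the numbers in this assay beyond the scatter, so no step beyond the scatter is expected for compound 4, with a 1.2-fold lower number from compound 3 to compound 4 (0.08 log units; within the scatter) as the expected movement. Compound 4 is estimated at 28000 nM, with a likely range from 14000 nM to 56000 nM.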

Compound 4, half-maximal inhibitory concentration: 18000 nM
For compound 4 the middle estimate is 1.6-fold (0.19 log units) above the measured one, and the stated range covers the measured number.
By their numbers in this assay, from the lowest: compounds 4, 2, 1 and 3 (each within the scatter of the next).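

Placing chloro where methyl stood on this benzyl ring gives a 1.9-fold lower number from compound 3 to compound 4 (0.28 log units; within the scatter) in this assay, so even this change leaves the number within the scatter. Chloro and trifluoromethyl at this ring position are also not told apart (a 1.1-fold lower number from compound 2 to compound 4 (0.02 log units; within the scatter)), and 3-chlorophenyl against 4-methylphenyl gives a 1.6-fold lower number from compound 1 to compound 4 (0.19 log units; within the scatter), so all four benzyl rings shown remain equivalent within the scatter. No supporting measurement is available to explain these numbers. As far as these compounds go, whether an amine or a carboxylic acid on this ring would move the number beyond the scatter remains open.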